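The source may hold more compounds than are shown below. What is called first, only, known or untested is meant among the compounds shown, and "the series" means these compounds.

Measured compounds:
- compound 1, `CCn1c(=O)c2nc(-c3ccc(S(=O)(=O)N4CCOCC4)cc3)[nH]c2n(CC)c1=O`, gives 13 nM
- compound 2, `Cc1ccc(-c2nc3c(=O)n(C)c(=O)n(C)c3[nH]2)c(N)c1`, gives 10 nM
- compound 3, `Cn1c(=O)c2nc(-c3ccc([N+](=O)[O-])cc3)[nH]c2n(C)c1=O`, gives 8 nM

All three numbers come from an assay for binding affinity to adenosine receptor A1 (Bos taurus); a higher number here means a weaker inhibitor, a lower number a stronger inhibitor. Compound 1 has the highest of the three numbers, but its gap to compound 2 and its gap to compound 3 both lie within the usual scatter of this assay, so the three compounds cannot be told apart on these numbers alone. Going by the values given here, no pair of them differs in only one place, so none of these values shows what any single change does.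

The unmeasured compound is compound 4, `CCn1c(=O)c2nc(-c3ccc(S(=O)(=O)NCCN(C)C)cc3)[nH]c2n(CC)c1=O`. It shares the core of compound 1 and differs from it in one place: (2-(dimethylamino)ethyl)amino in place of morpholin-4-yl on a sulfonyl sulfur. Among the compounds with values here, nothing among the measured compounds shows what such a change does in this assay, so the expectation rests on compound 1 alone. The step from compound 1 to compound 4 is expected to be small, in either direction or none beyond the scatter, estimated as a 1.3-fold lower number from compound 1 to compound 4 (0.11 log units; within the scatter). Compound 4 is therefore estimated at 10 nM, within a range from 4 nM to 30 nM.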

Compound 4, half-maximal inhibitory concentration: 3.3 nM
Estimate against measurement, compound 4: 3.0-fold (0.48 log units) above; the measured number lies below the stated range.
By their numbers in this assay, from the lowest: compound 4; then compounds 3, 2 and 1 (each within the scatter of the next).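

In this assay, going by these compounds alone, the change from morpholin-4-yl to (2-(dimethylamino)ethyl)amino on a sulfonyl sulfur is the first single change that can be read, and it gives a 3.9-fold lower number from compound 1 to compound 4 (0.60 log units; beyond the scatter). Within the data shown here, this shows that the number responds to what this position carries, which the earlier compounds could not show because no two of them differed in only one place. The two groups have the same heavy-atom count, so the step does not come with a change in that count, but the ring is lost, a hydrogen-bond donor is gained and a nitrogen replaces the oxygen, all at once; no measurement here explains the step.

The compounds shown leave open which of these differences matters, since all of them arrive together in one step. A 4-methylpiperazin-1-yl group on the same sulfonyl sulfur would keep a ring while carrying a second nitrogen, whereas a (2-methoxyethyl)amino chain would keep the open chain and the hydrogen-bond donor but end in an oxygen instead of the dimethylamino nitrogen.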